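Removing a methoxy from compound 3: an expectation for compound 4

A few compounds are considered here, and "the series" means these few. Any claim that something is new, unique, unknown or untested is made for them only; others in the source may bear on it.

Of the compounds shown here, three have been measured in an assay on HEK293 cells for displacement of a labelled ligand from Melanocortin receptor 4 (Homo sapiens); a lower number here means a stronger inhibitor, a higher number a weaker inhibitor. Compound 1, `CC(C)C[C@H](N)c1ccccc1N1CCN(C(=O)[C@H](C)Cc2ccc(Cl)cc2F)CC1`, gives 67 nM in this assay. Compound 2, `CC(C)C[C@H](N)c1cc(Cl)ccc1N1CCN(C(=O)C(C)Cc2ccc(Cl)cc2)CC1`, gives 67 nM in this assay. Compound 3, `COc1cc(CC(C)C(=O)N2CCN(c3ccc(C(F)(F)F)cc3[C@@H](N)CC(C)C)CC2)ccc1Cl`, gives 230 nM in this assay, the highest of the three numbers; its nearest neighbour is compound 1, and the gap to it, like the gap to compound 2, lies beyond the scatter.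

Compound 4 is `CC(C)C[C@H](N)c1cc(C(F)(F)F)ccc1N1CCN(C(=O)C(C)Cc2ccc(Cl)cc2)CC1`, not yet measured. It differs from compound 3 in one place: hydrogen in place of methoxy on an aromatic carbon. Going by the values given here, no pair of measured compounds shows this change on its own, so its size in this assay is not known. Compound 2, which also carries a hydrogen at that position, gives 67 nM in this assay, and compound 1, with a different benzyl pattern again, gives 67 nM; both of these numbers lie lower than the number for compound 3.

On that basis compound 4 is expected to move to a lower number than compound 3, with the step of a 2.3-fold lower number from compound 3 to compound 4 (0.36 log units; beyond the scatter) estimated to lie beyond the scatter. The estimate for compound 4 in this assay is 100 nM, within a range from 40 nM to 250 nM.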

Compound 4, inhibition constant: 47 nM
Compound 4: the middle estimate sits 2.1-fold (0.33 log units) above what was measured, within the range that was stated.
By their numbers in this assay, from the lowest: compounds 4, 1 and 2 (each within the scatter of the next); then compound 3.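

In this assay, hydrogen in place of methoxy on an aromatic carbon, ortho to a chloro group, gives a 4.9-fold lower number from compound 3 to compound 4 (0.69 log units; beyond the scatter), so the change from 4-chloro-3-methoxybenzyl to 4-chlorobenzyl now has a measured size of its own, with the rest of the molecule held fixed. Trifluoromethyl in place of chloro on an aromatic carbon gives a 1.4-fold lower number from compound 2 to compound 4 (0.15 log units; within the scatter), which lies within the scatter, so with 4-chlorobenzyl in place the two groups cannot be told apart here, and the high number of compound 3 goes with its methoxy and not with its trifluoromethyl. Nothing measured here gives a reason for the size of the methoxy step.

Going by these compounds, only methoxy and hydrogen appear at this position, so it remains open how a fluoro, a hydroxy or an ethoxy group would read there, and whether the number rises steadily with the size of the group or depends on the particular group. On these data alone, it also remains open whether the methoxy step has the same size when chloro takes the place of trifluoromethyl elsewhere in the molecule.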